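A few compounds are considered here, and "the series" means these few. Any claim that something is new, unique, unknown or untested is made for them only; others in the source may bear on it.

Working notes on the series. The shared core carries a propyl group and an amino group, and the amide nitrogen bears the variable part. Compound 1 `CCCc1cc(N)c2cc(NC(=O)c3ccc(-c4ccc(Cl)cc4)cc3)ccc2n1` gives 75 nM in a functional assay on HEK293 cells for activation of melanin-concentrating hormone receptor 1 (Homo sapiens), read by inositol phosphate accumulation; a higher number here means that more compound is needed for the effect, a lower number that less compound is needed; compound 3 `CCCc1cc(N)c2cc(NC(=O)c3ccc(-c4ccc(C(F)(F)F)cc4)cc3)ccc2n1` gives 310 nM; compound 2 `CCCc1cc(N)c2cc(NC(=O)/C=C/c3ccc(Cl)cc3Cl)ccc2n1` gives 904 nM. Compound 2 thus stands at the highest of the three numbers, nearest to compound 3 and furthest from compound 1.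

Going by the values given here, the one measured step in the set, a 4.1-fold higher number from compound 1 to compound 3 (0.62 log units; beyond the scatter), concerns the biphenyl amides and not the doubly bonded chain of compound 2. It shows that a change of one substituent on the distal ring can move the number by a modest amount.

Compound 4 `CCCc1cc(N)c2cc(NC(=O)/C=C/c3ccc(C(C)C)cc3)ccc2n1` is not yet measured. Its structure differs from compound 2 as follows: 4-isopropylphenyl in place of 2,4-dichlorophenyl on a double-bonded chain carbon bound to a double-bonded chain carbon. Among the compounds with values here, two chlorines leave and an isopropyl enters; no measured pair in the set mirrors this exchange, so the step from compound 1 to compound 3 bears on it only loosely, as a measure of how much a ring substituent change has moved this assay so far.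

For compound 4 the expectation is 1500 nM, with a range from 400 nM to 6000 nM, meaning an estimated step of a 1.7-fold higher number from compound 2 to compound 4 (0.22 log units; within the scatter), which may well fall within the scatter.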

Compound 4, half-maximal effective concentration: 520 nM
Estimate against measurement, compound 4: 2.9-fold (0.46 log units) above; the range from low to high includes it.
By their numbers in this assay, from the lowest: compound 1; then compounds 3, 4 and 2 (each within the scatter of the next, the first and the last beyond it).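

In this assay, going by these compounds alone, the exchange of 2,4-dichlorophenyl for 4-isopropylphenyl gives the first measured step at this place (a 1.7-fold lower number from compound 2 to compound 4 (0.24 log units; within the scatter)), so on a double-bonded chain carbon bound to a double-bonded chain carbon these two groups cannot be told apart. The earlier step, with trifluoromethyl in place of chloro, went beyond the scatter, whereas here two chlorines leave and an isopropyl enters with no change that the scatter does not cover; the two steps concern different compounds, however, and no general rule about ring substituents follows from them. No supporting measurement bears on why the two groups read alike.

On these data alone, it remains open whether this tolerance extends to groups of another kind, such as an amine or a carboxylic acid on the aromatic ring in place of isopropyl, or whether the number would then move beyond the scatter. Also open, as far as these compounds go, is whether 4-isopropylphenyl and 2,4-dichlorophenyl would still read alike on a longer chain in place of the double-bonded chain.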